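The compounds below may be only part of what the source reports. "The series", "measured", "known", "first", "only" and "open" are said of these compounds alone.

In a functional assay on OVCAR-8 cells (Homo sapiens) for antiproliferative activity (on this read-out lower numbers stand for stronger inhibition and higher numbers for weaker inhibition), compound 1 `Cn1ncc(Cl)c1-c1cc(C(=O)N[C@@H]2CN[C@H](CC(=O)NC3CC3)C[C@H]2c2ccc(Cl)c(Cl)c2)oc1Cl` gives 580 nM. Compound 2 `CC(=O)NCC[C@@H]1C[C@@H](c2ccc(F)c(F)c2)[C@H](NC(=O)c2cc(-c3c(Cl)cnn3C)c(Cl)o2)CN1` gives 880 nM in this assay, a number separated from compound 1's by less than the usual scatter, so the two stand level. Compound 3 `CC(=O)OCC[C@@H]1C[C@@H](c2ccc(F)c(F)c2)[C@H](NC(=O)c2cc(-c3c(Cl)cnn3C)c(Cl)o2)CN1` differs from compound 2 in one place: acetoxy in place of acetamido on a saturated chain carbon, two bonds along the chain from a saturated ring carbon. No measured pair isolates this exchange, so nothing among these compounds shows its effect. The expected step is a 1.3-fold higher number from compound 2 to compound 3 (0.10 log units; within the scatter), a small move toward a higher number that need not exceed the scatter. Compound 3 in this assay is therefore estimated at 1100 nM, within a range from 400 nM to 3000 nM.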

Compound 3, half-maximal inhibitory concentration: 4960 nM
For compound 3 the middle estimate is 4.5-fold (0.65 log units) below the measured one, and the stated range ends below it.
By their numbers in this assay, from the lowest: compounds 1 and 2 (each within the scatter of the next); then compound 3.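

In this assay, the place two bonds along the chain from a saturated ring carbon proves sensitive to this exchange: acetoxy in place of acetamido brings a 5.6-fold higher number from compound 2 to compound 3 (0.75 log units; beyond the scatter), a step beyond the scatter. The two groups match in heavy atoms, while acetoxy carries 0 hydrogen-bond donors where acetamido carries 1. Nothing at hand ties the step to that difference or to any other. From the compounds shown here alone, whether an amine, a carboxylic acid or a longer chain at this place would stand level with acetamido or with acetoxy remains open.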